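Working notes: amide variation, compound 2 to compound 3

The source may hold more compounds than are shown below. What is called first, only, known or untested is meant among the compounds shown, and "the series" means these compounds.

Values in a functional assay on HL-60 cells (Homo sapiens) for antiproliferative activity, read by MTT assay, with a stated time of 24 h (a higher number here means a weaker inhibitor, a lower number a stronger inhibitor), are as follows
- compound 1 `CCCCc1oc2ccccc2c1C(=O)c1ccc(OCCCC(=O)N2CCCC2)cc1` gives 29900 nM as a number
- compound 2 `CCCCc1oc2ccccc2c1C(=O)c1ccc(OCCCC(=O)N(C)Cc2ccccc2)cc1` gives > 50000 nM as a limit of the assay

Compound 2 stands at the limit of > 50000 nM in this assay, at which 1 of the 2 values shown sits, and is known only as a limit, not as a number.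

The change to compound 3 `CCCCc1oc2ccccc2c1C(=O)c1ccc(OCCCC(=O)N[C@H](C)c2ccccc2)cc1` is (1-phenylethyl)amino in place of benzyl(methyl)amino on a carbonyl carbon and puts (1-phenylethyl)amino in place of benzyl(methyl)amino on a carbonyl carbon.

Among the compounds with values here, the only measured step at this place is an at least 1.6-fold higher number from compound 1 to compound 2 (0.22 log units; that floor lies within the scatter) and it sets neither a firm size nor a firm direction for the new change. In this assay no step beyond the scatter can be firmly expected from it. Compound 1 at 29900 nM is the only numerical anchor, so compound 3 is expected to read near it. Compound 3 may instead be expected to reach the limit of the assay, as compound 2 does.

The expected change by this estimate is an at least 1.4-fold lower number from compound 2 to compound 3 (0.15 log units; that floor lies within the scatter) and its starting point is a limit.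

For compound 3 the estimated value is 35000 nM with an expected range from 12000 nM to 70000 nM in this series.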

Compound 3, half-maximal inhibitory concentration: > 50000 nM
Compound 3: a limit, no number (the forecaster's own chance of this, stated with the estimate: 40%); middle value at least 1.4-fold (0.15 log units) away from the limit.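

In this assay compound 3 gives > 50000 nM, a limit of the assay and not a number. Compound 2 is also a limit, so the step to compound 3 cannot be read, and bringing a hydrogen-bond donor and a defined stereocentre to this carbonyl carbon yields no numerical value. With (1-phenylethyl)amino in place of pyrrolidin-1-yl the record is an at least 1.6-fold higher number from compound 1 to compound 3 (0.22 log units; that floor lies within the scatter), so neither group carrying the six-membered aromatic ring is firmly separated from pyrrolidin-1-yl: the limit of > 50000 nM in this assay, at which 2 of the 3 values shown sit.

From the compounds shown here alone, how far compound 2 and compound 3 lie beyond the range of the assay, and whether they differ from each other, remains open. Also open, going by these compounds, is whether a morpholine amide, a piperidine amide or a free carboxylic acid at this carbonyl carbon would give a value within that range.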